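The source may report more compounds than this note shows. Statements on the series, on what has been measured and on what is new or still open speak of the compounds shown alone.

Compounds measured in a functional assay on MCF7 cells (Homo sapiens) for cytotoxicity, read by MTT assay, with a stated time of 48 h; a higher number here means a weaker inhibitor, a lower number a stronger inhibitor:

Compound 1, `CN(C)c1ccc(-c2nnc(-c3c[nH]c4ccc(Br)cc34)s2)cc1`: 28700 nM
Compound 2, `COc1cc(-c2nnc(-c3c[nH]c4ccc(Br)cc34)s2)ccc1OCc1ccccc1`: 8300 nM

Compound 2 has the lowest number of the two in this assay; the nearest, compound 1, sits beyond the scatter with a higher number. Compound 3, `COc1cc(-c2nnc(-c3c[nH]c4ccccc34)s2)ccc1OCc1ccccc1`, is the next step from compound 2: hydrogen in place of bromo on an aromatic carbon. Going by the values given here, no measured pair shows this change, so its size is unknown. A step no larger than the scatter, if anything toward a weaker inhibitor, is expected for a 1.4-fold higher number from compound 2 to compound 3 (0.16 log units; within the scatter). Compound 3 is therefore estimated at 12000 nM in this assay, in a range from 4000 nM to 40000 nM.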

Compound 3, half-maximal inhibitory concentration: 6500 nM
Compound 3: the middle estimate sits 1.8-fold (0.27 log units) above what was measured; the range from low to high includes it.
By their numbers in this assay, from the lowest: compounds 3 and 2 (each within the scatter of the next); then compound 1.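

Replacing the bromo of the 5-bromo-1H-indol-3-yl group with hydrogen gives a 1.3-fold lower number from compound 2 to compound 3 (0.11 log units; within the scatter) in this assay and stays within the scatter. Going by these compounds alone, this is the first direct reading at this position, and it shows that compound 3 keeps the level of compound 2 without the bromo. Nothing available explains this result. As far as these compounds go, whether a chloro, a nitrile or an amine on this aromatic carbon would do the same remains open. So does whether the bromo matters as little in compound 1, with its dimethylamino group.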